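This account rests on a few compounds, and the source may have more. Where it says the series, first, only, none or still open, it means among the compounds named here.

Measured in a functional assay on RAW264.7 cells (Mus musculus) for inhibition, read by polymerase chain reaction, with stated times of 12 h and 6 h; a lower number here means a stronger inhibitor, a higher number a weaker inhibitor:
- compound 1 `COc1ccc(CN2CCC(NC(=O)C(C)(C)CCCOc3cc(C)ccc3C)CC2)cc1`: 4150 nM
- compound 2 `Cc1ccc(C)c(OCCCC(C)(C)C(=O)NC2CCN(Cc3ccc(C(F)(F)F)cc3)CC2)c1`: 5170 nM
- compound 3 `Cc1ccc(CN2CCC(NC(=O)C(C)(C)CCCOc3cc(C)ccc3C)CC2)cc1`: 6540 nM

Compound 3, at 6540 nM, lies within the scatter of both compound 1 and compound 2, so the three cannot be ranked. Compound 4 `Cc1ccc(C)c(OCCCC(C)(C)C(=O)NC2CCN(Cc3ccc(F)cc3)CC2)c1` carries fluoro in place of methyl on an aromatic carbon, para to a large group: fluoro in place of methyl on an aromatic carbon.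

Three measured exchanges on that same aromatic carbon bear on this: a 1.2-fold higher number from compound 1 to compound 2 (0.10 log units; within the scatter), a 1.6-fold higher number from compound 1 to compound 3 (0.20 log units; within the scatter) and a 1.3-fold higher number from compound 2 to compound 3 (0.10 log units; within the scatter). All three lie within the scatter, so no step beyond the scatter is expected in this assay, in either direction. The expected size is a 1.3-fold lower number from compound 3 to compound 4 (0.12 log units; within the scatter). Compound 4 is estimated at 5000 nM, with an expected range of 2800 nM to 9000 nM.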

Compound 4, half-maximal inhibitory concentration: 4560 nM
Compound 4: the middle estimate sits 1.1-fold (0.04 log units) above what was measured; low and high end bracket the measured number.
By their numbers in this assay, from the lowest: compounds 1, 4, 2 and 3 (each within the scatter of the next).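

In this assay, fluoro gives a fourth substituent on this aromatic carbon, and every new step lies within the scatter (a 1.4-fold lower number from compound 3 to compound 4 (0.16 log units; within the scatter); a 1.1-fold lower number from compound 2 to compound 4 (0.05 log units; within the scatter); a 1.1-fold higher number from compound 1 to compound 4 (0.04 log units; within the scatter)). Methoxy, trifluoromethyl, methyl and fluoro therefore cannot be ranked at this carbon, and the position has not yet shown a step beyond the scatter. No measurement at hand accounts for this flat result.

Open, on these data alone, is whether a carboxylic acid, an amine or a longer chain on this carbon would give a step beyond the scatter. Also open, as far as these compounds go, is whether changes elsewhere on the shared core would do so in this assay.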